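The source may report more compounds than this note shows. Statements on the series, on what has been measured and on what is new or still open speak of the compounds shown alone.

Measured compounds:
- compound 1 `COc1ccc(S(=O)(=O)N2CCc3cccc(NC(=O)c4ccc(C#N)cc4)c32)cc1`: 105 nM
- compound 2 `COc1ccc(S(=O)(=O)N2CCc3cccc(NC(=O)c4ccc([N+](=O)[O-])cc4)c32)cc1`: 102 nM
- compound 3 `COc1ccc(C(=O)Nc2cccc3c2N(S(=O)(=O)c2ccc(OC)cc2)CC3)cc1`: 2600 nM

In a functional assay on KB cells (Homo sapiens) for cytotoxicity (a lower number here means a stronger inhibitor, a higher number a weaker inhibitor), compound 2 gives the lowest of the three numbers, but its step to compound 1 is within the scatter, a 1.0-fold lower number from compound 1 to compound 2 (0.01 log units; within the scatter), so the two cannot be ordered. Compound 3 stands far apart: a 25-fold higher number from compound 2 to compound 3 (1.41 log units; beyond the scatter) and a 25-fold higher number from compound 1 to compound 3 (1.39 log units; beyond the scatter). Compound 4 `COc1ccc(S(=O)(=O)N2CCc3cccc(NC(=O)c4ccco4)c32)cc1` carries the change (furan-2-yl in place of 4-nitrophenyl on a carbonyl carbon). Within the data shown here, no measured step replaces the whole aryl group, so none bears on it directly. The two steps to compound 3 show that giving up the nitro or cyano group costs a great deal, and compound 4 gives up the nitro group together with the six-membered ring. A large step upward is therefore expected, a 29-fold higher number from compound 2 to compound 4 (1.47 log units; beyond the scatter), and compound 4 is estimated at 3000 nM, between 600 nM and 15000 nM.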

Compound 4, half-maximal inhibitory concentration: 9.6 nM
Compound 4: the middle estimate sits 310-fold (2.49 log units) above what was measured; the whole stated range lies above it.
By their numbers in this assay, from the lowest: compound 4; then compounds 2 and 1 (each within the scatter of the next); then compound 3.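

In this assay the group on the carbonyl carbon does not need a nitro or nitrile substituent, or even a six-membered ring, for a low number: furan-2-yl in compound 4 gives steps (an 11-fold lower number from compound 2 to compound 4 (1.03 log units; beyond the scatter)) and (an 11-fold lower number from compound 1 to compound 4 (1.04 log units; beyond the scatter)) and, against the methoxy compound, (a 270-fold lower number from compound 3 to compound 4 (2.43 log units; beyond the scatter)). Compound 4 therefore has the lowest number of the four, with all its steps beyond the scatter. Nothing available here accounts for this gain. The compounds shown leave open whether the ring oxygen of furan-2-yl matters, as thiophen-2-yl, with sulfur in its place, would test. They also leave open whether a saturated tetrahydrofuran-2-yl ring would serve as well.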